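Replacing a short chain by a methyl-bearing aryl ring

This account rests on a few compounds, and the source may have more. Where it says the series, first, only, none or still open, it means among the compounds named here.

Measured compounds:
Compound 1 `CCC(=O)Nc1c(C(O)(C(F)(F)F)C(F)(F)F)ccc2ccccc12` gives 8.91 nM in a functional assay (Sus scrofa) with sulfonylurea receptors; K-ATP channels (Homo sapiens) as the target; a lower number here means that less compound is needed, a higher number that more compound is needed for the effect.
Compound 2 `CCCC(=O)Nc1c(C(O)(C(F)(F)F)C(F)(F)F)ccc2ccccc12` gives 708 nM in this assay.
Compound 3 `O=C(Nc1c(C(O)(C(F)(F)F)C(F)(F)F)ccc2ccccc12)c1cccc(Cl)c1` gives 851 nM in this assay.

Compound 1 stands lowest of the three, with a 79-fold higher number from compound 1 to compound 2 (1.90 log units; beyond the scatter) and a 96-fold higher number from compound 1 to compound 3 (1.98 log units; beyond the scatter) both beyond the scatter. Compound 4 `Cc1cccc(C(=O)Nc2c(C(O)(C(F)(F)F)C(F)(F)F)ccc3ccccc23)c1` differs from compound 1 by 3-methylphenyl in place of ethyl on a carbonyl carbon. The step that bears most directly on this change is a 96-fold higher number from compound 1 to compound 3 (1.98 log units; beyond the scatter), where a 3-chlorophenyl replaced the ethyl on the same carbonyl carbon; compound 2 also shows that lengthening the chain gave a 79-fold higher number from compound 1 to compound 2 (1.90 log units; beyond the scatter). A 3-methylphenyl is expected to behave much like the 3-chlorophenyl, so a large rise is expected, a 79-fold higher number from compound 1 to compound 4 (1.90 log units; beyond the scatter). Compound 4 is therefore estimated at 700 nM, within 150 nM to 3000 nM.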

Compound 4, half-maximal effective concentration: 52.5 nM
The estimate for compound 4 lay 13-fold (1.12 log units) above the measured number; the whole stated range lies above it.
By their numbers in this assay, from the lowest: compound 1; then compound 4; then compounds 2 and 3 (each within the scatter of the next).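

A ring on this carbonyl carbon need not cost much: the rise is modest (a 5.9-fold higher number from compound 1 to compound 4 (0.77 log units; beyond the scatter)), whereas the 3-chlorophenyl group gave a large one. The group carried on the ring matters greatly, as methyl in place of chloro gives a large drop (a 16-fold lower number from compound 3 to compound 4 (1.21 log units; beyond the scatter)), and the 3-methylphenyl group also stands well under the propyl chain (a 13-fold lower number from compound 2 to compound 4 (1.13 log units; beyond the scatter)). No measurement at hand explains these differences.

From the compounds shown here alone, whether a plain phenyl ring, or a methoxy or amino group in place of the methyl, would keep the number low remains open.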